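The source may report more compounds than this note shows. Statements on the series, on what has been measured and on what is new or still open speak of the compounds shown alone.

Working notes on the series. Compound 2 `O=C(Nc1cc(C(F)(F)F)cc(C(F)(F)F)c1)c1cc(I)ccc1O` is the anchor of the step considered here. Among the measured compounds shown here, in an ADME assay on cells (Macrophage, Mus musculus) for cytotoxicity, read by resazurin assay, with a stated time of 3 days (on this read-out higher numbers stand for weaker inhibition and lower numbers for stronger inhibition), compound 2 gives 5600 nM, the only finite number in this set. Compound 1 `O=C(Nc1cc(C(F)(F)F)cc(C(F)(F)F)c1)c1cccc(Cl)c1` returns only a limit in this assay, namely > 60000 nM. the limit of > 60000 nM in this assay, at which 1 of the 2 values shown sits, is where compound 1 sits. For the measured compounds named here, the one measured step, an at least 10-fold lower number from compound 1 to compound 2 (1.02 log units; beyond the scatter), is a change of the ring on the carbonyl carbon and reads as large, though it starts from a limit and its true size is open.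

Compound 3 `O=C(Nc1cc(C(F)(F)F)cc(C(F)(F)F)c1)c1cccc(O)c1O` differs from compound 2 by 2,3-dihydroxyphenyl in place of 2-hydroxy-5-iodophenyl on a carbonyl carbon. Going by the values given here, this change touches the same ring on the carbonyl carbon as the measured step, but no measured pair shows what the 2,3-dihydroxyphenyl ring does there, and an at least 10-fold lower number from compound 1 to compound 2 (1.02 log units; beyond the scatter) alters several features at once, so it points a direction only loosely. For compound 3 the expected step is a 3.6-fold higher number from compound 2 to compound 3 (0.55 log units; beyond the scatter), a moderate rise in the number with wide uncertainty. The estimate for compound 3 in this assay is 20000 nM, in the range 5000 nM to 60000 nM, with a real chance that only a limit is returned.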

Compound 3, half-maximal inhibitory concentration: 1700 nM
Compound 3: the middle estimate sits 12-fold (1.07 log units) above what was measured; the whole stated range lies above it.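

In this assay iodine is not required for a finite number on this ring: 2,3-dihydroxyphenyl in place of 2-hydroxy-5-iodophenyl on the carbonyl carbon gives a 3.3-fold lower number from compound 2 to compound 3 (0.52 log units; beyond the scatter), so this change moves the read-out towards stronger inhibition. Against the 3-chlorophenyl ring, the 2,3-dihydroxyphenyl ring gives an at least 35-fold lower number from compound 1 to compound 3 (1.54 log units; beyond the scatter), and among the three rings shown, the two carrying a hydroxy group give finite numbers, with no compound here going against that. On these data alone, the true size of this second step stays open because compound 1 returns only a limit: the limit of > 60000 nM in this assay, at which 1 of the 3 values shown sits.

The compounds shown leave open whether the lower number follows the added hydroxy group or the loss of the iodine, as the two change together in this step. A plain 2-hydroxyphenyl ring would separate the two, and a methoxy group or a carboxylic acid in place of a hydroxy group would test whether the hydroxy group itself is what matters on this ring.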